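The source may hold more compounds than are shown below. What is called first, only, known or untested is meant among the compounds shown, and "the series" means these compounds.

Series notes. For the measured compounds named here, compound 2 `CN1CCN(CCn2c(N)c(-c3nc4ccccc4[nH]3)c3nc(C#N)c(C#N)nc32)CC1` carries the shared core with a 2-(4-methylpiperazin-1-yl)ethyl chain; in a functional assay on HL60/MX2 cells (Homo sapiens) for antiproliferative activity, read by MTT assay, with a stated time of 48 h (on this read-out lower numbers stand for stronger inhibition and higher numbers for weaker inhibition), compound 2 gives 6490 nM, the only outright number among the three measured compounds. Compound 1 `CCn1c(N)c(-c2nc3ccccc3[nH]2)c2nc(C#N)c(C#N)nc21` reaches only > 50000 nM, a limit of the assay. Compound 3 `CCCn1c(N)c(-c2nc3ccccc3[nH]2)c2nc(C#N)c(C#N)nc21` likewise stops at > 50000 nM, also a limit. The steps of an at least 7.7-fold lower number from compound 1 to compound 2 (0.88 log units; beyond the scatter) and an at least 7.7-fold higher number from compound 2 to compound 3 (0.88 log units; beyond the scatter) point the same way: the number is lower only where the 4-methylpiperazin-1-yl is present, and the limit of > 50000 nM in this assay, at which 2 of the 3 values shown sit, is where both compounds lacking it sit. Compound 4 `N#Cc1nc2c(-c3nc4ccccc4[nH]3)c(N)n(CCCO)c2nc1C#N` differs from compound 2 by hydroxymethyl in place of 4-methylpiperazin-1-yl on a saturated chain carbon, two bonds along the chain from an aromatic nitrogen. With the 4-methylpiperazin-1-yl gone, a higher number is expected, and a 3.9-fold higher number from compound 2 to compound 4 (0.59 log units; beyond the scatter) is the expected size of that move. Compound 4 is thus estimated at 25000 nM, in the range 6000 nM to 100000 nM.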

Compound 4, half-maximal inhibitory concentration: > 50000 nM
Compound 4 gave a limit, no number; the forecaster's own chance of this, stated with the estimate: 45%; at least 2.0-fold (0.30 log units) between middle value and limit.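

Replacing the 2-(4-methylpiperazin-1-yl)ethyl chain with 3-hydroxypropyl gives an at least 7.7-fold higher number from compound 2 to compound 4 (0.88 log units; beyond the scatter) in this assay, so a hydroxy-ended chain does not restore a measurable number at this position. Compound 4 gives > 50000 nM, which is a limit, so the steps linking compound 1, compound 3 and compound 4 cannot be read. The 4-methylpiperazin-1-yl chain remains the only one shown to yield a number, with the others at the same limit: the limit of > 50000 nM in this assay, at which 3 of the 4 values shown sit.

The compounds shown leave open whether a simpler amine such as dimethylamino, or a morpholin-4-yl ring, on the same chain would also yield a number. As far as these compounds go, the effect of a longer chain carrying 4-methylpiperazin-1-yl also remains open.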